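One group exchanged on compound 2

The compounds below may be only part of what the source reports. "The series", "measured", "known", "first", "only" and "open" are said of these compounds alone.

In a functional assay with Oryctolagus cuniculus as the target (a higher number here means a weaker inhibitor, a lower number a stronger inhibitor), compound 1 `COc1ccc(-c2nc(N=C(N)N)sc2-c2ccc(OC)cc2)cc1` gives 31000 nM, a weak result. Compound 2 `COc1ccc(-c2nc(CNC(=O)CSc3ccccc3)sc2-c2ccc(OC)cc2)cc1` returns only a limit, < 100 nM. Among the measured compounds shown here, that limit places compound 2 at the strong, low-number end of the two compounds measured so far.

Compound 3 `CNC(=O)NCc1nc(-c2ccc(OC)cc2)c(-c2ccc(OC)cc2)s1` has not yet been tested. It keeps the shared core and carries methylamino in place of (phenylsulfanyl)methyl on a carbonyl carbon. For the measured compounds named here, no measured pair shows this exchange, so any expectation here is rough. Compound 1 at 31000 nM shows that the shared core alone does not secure strong inhibition, so the group being lost may matter. The estimated step of an at least 8.0-fold higher number from compound 2 to compound 3 (0.90 log units; beyond the scatter) is expected to run toward weaker inhibition, beyond the scatter but moderate in size. For compound 3 the expected value is 800 nM, with an estimated range from 100 nM to 6000 nM.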

Compound 3, half-maximal inhibitory concentration: 22 nM
Compound 3: the middle estimate sits 36-fold (1.56 log units) above what was measured, and the stated range ends above it.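

In this assay, the (phenylsulfanyl)methyl group and its aromatic ring are not needed for strong inhibition: with only methylamino on the carbonyl carbon, compound 3 gives 22 nM. Changing the group on the aromatic carbon of the shared core also matters greatly, producing a 1400-fold lower number from compound 1 to compound 3 (3.15 log units; beyond the scatter), a large move toward stronger inhibition. Compound 2 has only a limit, so its step to compound 3 cannot be read, and which of the two is stronger stays unknown: the limit of < 100 nM in this assay, at which 1 of the 3 values shown sits.

The compounds shown leave open how much the group on the carbonyl carbon can change, for instance whether ethylamino or dimethylamino in place of methylamino would keep inhibition this strong. They also leave open whether the methoxy groups matter, which a compound with hydroxy or chloro in their place could test.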